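Swapping Chloro for Trifluoromethyl at the Assay Limit

This account rests on a few compounds, and the source may have more. Where it says the series, first, only, none or still open, it means among the compounds named here.

Of the compounds shown here, two sharing one core have been tested in a functional assay on HeLa cells (Homo sapiens) for cytotoxicity, read by MTT assay, with a stated time of 24 h; a higher number here means a weaker inhibitor, a lower number a stronger inhibitor. Compound 2 `CN1C/C(=C\c2ccc(Cl)cc2)C(=O)/C(=C/c2cccc([N+](=O)[O-])c2)C1` gives > 20000 nM, which is a limit of the assay and not a number. Compound 1 `CN1C/C(=C\c2ccc(C(F)(F)F)cc2)C(=O)/C(=C/c2ccccc2F)C1`, which carries a trifluoromethyl group, gives a true number of 6560 nM. Compound 3 `CN1C/C(=C\c2ccc(C(F)(F)F)cc2)C(=O)/C(=C/c2cccc([N+](=O)[O-])c2)C1` keeps compound 2 unchanged except for trifluoromethyl in place of chloro on an aromatic carbon. Among the compounds with values here, no measured pair isolates this swap, so only a modest shift towards stronger inhibition is expected, an at least 1.4-fold lower number from compound 2 to compound 3 (0.15 log units; that floor lies within the scatter). The estimated value for compound 3 is 14000 nM, within a range of 5000 nM to 30000 nM.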

Compound 3, half-maximal inhibitory concentration: 3560 nM
Compound 3: the middle estimate sits 3.9-fold (0.59 log units) above what was measured, and the stated range ends above it.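

At this position, trifluoromethyl in place of chloro gives an at least 5.6-fold lower number from compound 2 to compound 3 (0.74 log units; beyond the scatter) in this assay. The value of compound 2 is a limit of the assay and not a number, so this step has a floor but no known full size: the limit of > 20000 nM in this assay, at which 1 of the 3 values shown sits. With trifluoromethyl kept, 3-nitrophenyl in place of 2-fluorophenyl gives a 1.8-fold lower number from compound 1 to compound 3 (0.27 log units; within the scatter), so that swap does not separate these two compounds.

On these data alone, how an amine or a carboxylic acid would fare at this position remains open. So does whether the trifluoromethyl step would hold with 2-fluorophenyl in place of 3-nitrophenyl.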